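This account rests on a few compounds, and the source may have more. Where it says the series, first, only, none or still open, it means among the compounds named here.

Three compounds on the shared core of compound 1 `Cc1ccc2[nH]c(=O)c(CN(Cc3ccc(F)cc3)Cc3ccc(C(C)(C)C)cc3)cc2c1` have been taken through a toxicity assay on MDCK cells (Canis lupus familiaris) for cytotoxicity, read by crystal violet staining, with a stated time of 48 h; a lower number here means that less compound is tolerated, a higher number that more compound is tolerated. In this assay compound 1 gives > 27000 nM, which is a limit of the assay and not a number. Compound 2 `Cc1ccc2[nH]c(=O)c(CN(Cc3ccc(OCC(=O)O)cc3)Cc3ccc(C(C)(C)C)cc3)cc2c1` carries carboxymethoxy in place of fluoro on an aromatic carbon; in this assay compound 2 gives > 10000 nM, again a limit rather than a number. Compound 3 `Cc1ccc2[nH]c(=O)c(CN(Cc3ccc(SC(F)(F)F)cc3)Cc3ccc(C(C)(C)C)cc3)cc2c1` carries (trifluoromethyl)sulfanyl in place of fluoro on an aromatic carbon; in this assay compound 3 gives > 5000 nM, also a limit. Compound 3 thus stands at a limit, and the two further values shown are limits as well, sitting at the limit of > 27000 nM in this assay, at which 1 of the 3 values shown sits, the limit of > 10000 nM in this assay, at which 1 of the 3 values shown sits, and (the limit of > 5000 nM in this assay, at which 1 of the 3 values shown sits). The steps a step that the two limits leave unreadable from compound 1 to compound 2, a step that the two limits leave unreadable from compound 1 to compound 3 and a step that the two limits leave unreadable from compound 2 to compound 3 consequently carry no readable size in either direction.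

Compound 4 `Cc1ccc2[nH]c(=O)c(CN(Cc3ccc(C(C)(C)C)cc3)C(C)c3ccc(N(C)C)c(Cl)c3)cc2c1` differs from compound 3 by 1-(3-chloro-4-(dimethylamino)phenyl)ethyl in place of 4-((trifluoromethyl)sulfanyl)benzyl on an amine nitrogen. For the measured compounds named here, none of the measured steps bears readably on this change, all three being unreadable between limits, so the step that the limit leaves unreadable from compound 3 to compound 4 is expected to be none beyond the scatter, with a fair chance that only a limit is returned again. Compound 4 is therefore estimated at 20000 nM, within a range from 5000 nM to 60000 nM.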

Compound 4, half-maximal cytotoxic concentration: 9800 nM
Compound 4: middle estimate off by 2.0-fold (0.31 log units), on the high side; measured number inside the range.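

In this assay compound 4 gives 9800 nM and this is the only number among the four compounds shown, so 1-(3-chloro-4-(dimethylamino)phenyl)ethyl on the amine nitrogen gives this position its first readable value. Compound 1, compound 2 and compound 3 each stand at a limit of the assay. Set against 4-fluorobenzyl, the change gives an at least 2.7-fold lower number from compound 1 to compound 4 (0.44 log units; beyond the scatter) and so shows that the group at this position can move the tolerated concentration, while set against 4-(carboxymethoxy)benzyl it gives only an at least 1.0-fold lower number from compound 2 to compound 4 (0.00 log units; that floor lies within the scatter) and so shows no shift that can be told from the scatter. The step from 4-((trifluoromethyl)sulfanyl)benzyl cannot be read, and neither can any of the steps among the three earlier compounds.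

From the compounds shown here alone, the entering group differs from the others in its branching methyl, its chlorine and its dimethylamino group all at once, so it remains open which of these goes with the lower number, and an unbranched benzyl group carrying the same chlorine and dimethylamino group would be needed to separate the methyl from the rest. The values shown give no measured property that accounts for the change at this position.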